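The compounds below may be only part of what the source reports. "The series", "measured", "known", "first", "only" and "open" are said of these compounds alone.

Among the measured compounds shown here, in a physicochemical assay for solubility (on this read-out higher numbers stand for higher solubility and lower numbers for lower solubility), compound 1 `CC(=O)NCC(=O)N1CCc2c(C)c3c(n2-c2ccc(C(N)=O)c(c2)N[C@@H](C)CC1)CC(C)(C)CC3=O` gives 5 ug/mL, the only actual number available so far. Compound 2 `Cc1c2c(n3c1CC(=O)NCC[C@H](C)Nc1cc-3ccc1C(N)=O)CC(C)(C)CC2=O` reads > 100 ug/mL in this assay, which is a limit and not a number. Compound 1 therefore holds the lower of the two readings.

Compound 3 `Cc1c2c(n3c1CCN(C(=O)[C@@H](C)N)CC[C@H](C)Nc1cc-3ccc1C(N)=O)CC(C)(C)CC2=O` keeps the core of compound 1 and differs from it in one place: 1-aminoethyl in place of acetamidomethyl on a carbonyl carbon. In words, 1-aminoethyl stands in place of acetamidomethyl on a carbonyl carbon, so that (acetamidomethyl)carbonyl becomes (1-aminoethyl)carbonyl, on an amide-type nitrogen in a ring.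

For the measured compounds named here, no measured pair isolates this change, so any forecast in this assay is indirect. A rise beyond the scatter is nevertheless expected. Going by the values given here, that expectation leans on compound 2, whose reading of > 100 ug/mL is again a limit, and it carries no measured step for this change. The expected step of a 10-fold higher number from compound 1 to compound 3 (1.00 log units; beyond the scatter) is upward, and it is only an estimate. The estimate for compound 3 is 50 ug/mL, with an expected range of 15 ug/mL to 100 ug/mL.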

Compound 3, solubility: > 100 ug/mL
Compound 3: a limit, no number; the forecaster's own chance of this, stated with the estimate: 30%; middle value at least 2.0-fold (0.30 log units) away from the limit.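

Among the compounds shown here, compound 1 and compound 3 give the first measured step at this place on the core of compound 1: with 1-aminoethyl in place of acetamidomethyl on a carbonyl carbon, this assay shows an at least 20-fold higher number from compound 1 to compound 3 (1.30 log units; beyond the scatter), a step beyond the usual scatter. The exchange takes the group on this carbonyl carbon from 5 heavy atoms to 3 and adds a defined stereocentre, while the counts of hydrogen-bond donors and acceptors stay the same. Compound 3 reads > 100 ug/mL, which is a limit and not a number, and the full size of the step cannot be read past it: the limit of > 100 ug/mL in this assay, at which 2 of the 3 values shown sit.

The compounds shown leave open which part of the exchange carries the step, since the shorter group, the amine and the stereocentre all change together. Also open, as far as these compounds go, is how an aminomethyl group, the mirror-image 1-aminoethyl group, a longer chain ending in an amine or a carboxylic acid would read on this carbonyl carbon, and any ranking among compounds at this limit would need a reading that falls inside the range of the assay.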